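Sulfonylurea series: methylphenyl isomer at the arylamine nitrogen

A few compounds are considered here, and "the series" means these few. Any claim that something is new, unique, unknown or untested is made for them only; others in the source may bear on it.

Within the data shown here, compound 2 `Cc1ccccc1Nc1ccc(C#N)cc1S(=O)(=O)NC(=O)NC(C)(C)C` gives the lowest of the two numbers so far in a functional assay on HEK293 cells for antagonist activity at thromboxane A2 receptor (Homo sapiens), read by fluorescence and calcium flux (a lower number here means a stronger inhibitor, a higher number a weaker inhibitor), at 2750 nM. Among the measured compounds shown here, compound 1 `CC(C)(C)NC(=O)NS(=O)(=O)c1cc(C#N)ccc1Oc1ccc(Cl)cc1` gives 5640 nM in this assay, and the step of a 2.1-fold lower number from compound 1 to compound 2 (0.31 log units; beyond the scatter) is the only measured step in the set. Compound 3 `Cc1ccc(Nc2ccc(C#N)cc2S(=O)(=O)NC(=O)NC(C)(C)C)cc1` differs from compound 2 by 4-methylphenyl in place of 2-methylphenyl on a nitrogen on an aromatic ring. For the measured compounds named here, no measured step moves a methyl within the phenyl group on the nitrogen: the one step known, a 2.1-fold lower number from compound 1 to compound 2 (0.31 log units; beyond the scatter), exchanges the whole group on the aromatic carbon and so bears on the change to compound 3 only loosely. Nothing in the data therefore points to a step beyond the scatter in this assay, in either direction, and the expectation is a number close to that of compound 2. For compound 3 the estimate is 2800 nM, within 1000 nM to 8000 nM, which means an expected step of a 1.0-fold higher number from compound 2 to compound 3 (0.01 log units; within the scatter).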

Compound 3, half-maximal inhibitory concentration: 850 nM
Compound 3: middle estimate off by 3.3-fold (0.52 log units), on the high side; measured number below the stated range.
By their numbers in this assay, from the lowest: compound 3; then compound 2; then compound 1.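

In this assay, moving the methyl from 2-methylphenyl to 4-methylphenyl on the nitrogen gives a 3.2-fold lower number from compound 2 to compound 3 (0.51 log units; beyond the scatter) and leaves the atom counts unchanged, so this position distinguishes between the two methylphenyl isomers. The exchange of 4-chlorophenoxy for (4-methylphenyl)amino on the aromatic carbon gives a 6.6-fold lower number from compound 1 to compound 3 (0.82 log units; beyond the scatter) and is now the widest step in the series, showing that the result of that exchange depends on which methylphenyl isomer enters. No measured evidence bearing on the cause of the isomer difference is available.

On these data alone, whether a longer group at the same place, as in 4-ethylphenyl or 4-methoxyphenyl, would follow 4-methylphenyl remains open. Also open, as far as these compounds go, is how (4-chlorophenyl)amino would compare, which would separate the effect of the chlorine from that of the oxygen-to-nitrogen exchange.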